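This account rests on a few compounds, and the source may have more. Where it says the series, first, only, none or still open, it means among the compounds named here.

For the measured compounds named here, the three compounds measured so far share one core and differ only in the aryl group on an oxygen on an aromatic ring. Compound 1 `Cc1nn(C)c(Oc2ccc(F)cc2)c1/C=N\CCCCCCOc1cc2oc(=O)cc(C)c2cc1Cl` gives 16700 nM in a functional assay on U-87MG ATCC cells for antiproliferative activity against U-87 MG (Homo sapiens), read by MTT assay, with a stated time of 72 h; a lower number here means a stronger inhibitor, a higher number a weaker inhibitor. For compound 2 `Cc1nn(C)c(Oc2cccc(F)c2F)c1/C=N\CCCCCCOc1cc2oc(=O)cc(C)c2cc1Cl` the value in this assay is a limit of the assay, > 25000 nM. For compound 3 `Cc1nn(C)c(Oc2ccc(F)cc2F)c1/C=N\CCCCCCOc1cc2oc(=O)cc(C)c2cc1Cl` the value in this assay is likewise a limit, > 25000 nM. Compound 3 thus stands at the limit of > 25000 nM in this assay, at which 2 of the 3 values shown sit. The measured steps read an at least 1.4-fold higher number from compound 1 to compound 2 (0.17 log units; that floor lies within the scatter), an at least 1.4-fold higher number from compound 1 to compound 3 (0.17 log units; that floor lies within the scatter) and a step that the two limits leave unreadable from compound 2 to compound 3. Compound 4 `Cc1nn(C)c(Oc2cccc(Cl)c2)c1/C=N\CCCCCCOc1cc2oc(=O)cc(C)c2cc1Cl` differs from compound 3 by 3-chlorophenyl in place of 2,4-difluorophenyl on an oxygen on an aromatic ring. Going by the values given here, no measured step alters the aryl group in this way, and two of them end at a limit, so no direction is readable. The step to compound 4 in this assay is therefore expected to be an at least 1.2-fold lower number from compound 3 to compound 4 (0.09 log units; that floor lies within the scatter). Compound 4 is estimated at 20000 nM, between 8000 nM and 60000 nM.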

Compound 4, half-maximal inhibitory concentration: 8460 nM
Compound 4: the middle estimate sits 2.4-fold (0.37 log units) above what was measured; the range from low to high includes it.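

Unlike the earlier steps, the change to 3-chlorophenyl on this oxygen gives a reading beyond the scatter in this assay: an at least 2.9-fold lower number from compound 3 to compound 4 (0.47 log units; beyond the scatter) and an at least 2.9-fold lower number from compound 2 to compound 4 (0.47 log units; beyond the scatter). Against the 4-fluorophenyl group, the same change reads a 2.0-fold lower number from compound 1 to compound 4 (0.30 log units; within the scatter), so compound 1 and compound 4 cannot be told apart. Compound 2 and compound 3 remain limits of the assay, so those two steps give only a floor: the limit of > 25000 nM in this assay, at which 2 of the 4 values shown sit.

The compounds shown leave open how an unsubstituted phenyl or a bromophenyl group would read on this oxygen.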